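Trimming tert-Butyl to Methyl on the Outer Phenyl Ring

The compounds below may be only part of what the source reports. "The series", "measured", "known", "first", "only" and "open" are said of these compounds alone.

Compound 1, `O=C1NC(O)(CCn2cc(-c3ccccc3)nn2)C(OCc2ccccc2)=C1OCc1ccccc1`, gives 21100 nM in a functional assay on MDA-MB-231 cells (Homo sapiens) for antiproliferative activity, read by MTT assay, with a stated time of 24 h; a lower number here means a stronger inhibitor, a higher number a weaker inhibitor. Compound 2, `CC(C)(C)c1ccc(-c2cn(CCC3(O)NC(=O)C(OCc4ccccc4)=C3OCc3ccccc3)nn2)cc1`, gives > 100000 nM in this assay, which is a limit of the assay rather than a measured number.

The two measured compounds share one core and differ only on the outer phenyl ring. Adding tert-butyl in place of hydrogen there gave an at least 4.7-fold higher number from compound 1 to compound 2 (0.67 log units; beyond the scatter), so compound 2 is the weaker of the two, sitting at the limit of > 100000 nM in this assay, at which 1 of the 2 values shown sits; because of the limit of > 100000 nM in this assay, at which 1 of the 2 values shown sits, the true size of that step is not known.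

Compound 3, `Cc1ccc(-c2cn(CCC3(O)NC(=O)C(OCc4ccccc4)=C3OCc3ccccc3)nn2)cc1`, differs from compound 2 by methyl in place of tert-butyl on an aromatic carbon. Within the data shown here, only the step from compound 1 to compound 2 bears on this change, and methyl lies between hydrogen and tert-butyl in size. The expected outcome is therefore a number below the limit of compound 2 but not as low as compound 1, giving an estimated step of an at least 2.0-fold lower number from compound 2 to compound 3 (0.30 log units; that floor lies within the scatter). Compound 3 is expected to give about 50000 nM, within a range of 15000 nM to 200000 nM.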

Compound 3, half-maximal inhibitory concentration: 82200 nM
Estimate against measurement, compound 3: 1.6-fold (0.22 log units) below; low and high end bracket the measured number.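

Replacing hydrogen with methyl on the outer phenyl ring gives a 3.9-fold higher number from compound 1 to compound 3 (0.59 log units; beyond the scatter) in this assay, so a weaker result at this position does not require a group as large as tert-butyl. Trimming tert-butyl to methyl gives an at least 1.2-fold lower number from compound 2 to compound 3 (0.08 log units; that floor lies within the scatter), and this floor alone does not establish that the smaller group recovers any activity. Compound 2 stands at a limit rather than a measured number, so the true distance between the tert-butyl and methyl compounds remains unknown: the limit of > 100000 nM in this assay, at which 1 of the 3 values shown sits.

The three compounds shown carry only hydrogen or a carbon-only group at this place, so it remains open whether any substituent there gives a weaker result or only these alkyl groups do. A fluorine, a methoxy group or an amine on the same aromatic carbon would test this, and a group such as ethyl would help show how the result changes between methyl and tert-butyl.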